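The compounds below may be only part of what the source reports. "The series", "measured", "known", "first", "only" and "open" are said of these compounds alone.

Two compounds share a core in which a pyrazole bearing a methoxy-substituted phenyl carries a propenone linked to an aryl ring. Compound 1 `COc1ccc(-c2cc(/C=C/C(=O)c3ccc(N)cc3)[nH]n2)cc1` gives 1890 nM in a functional assay on SN12C cells (Homo sapiens) for inhibition, read by sulforhodamine B assay, with a stated time of 48 h; on this read-out higher numbers stand for weaker inhibition of growth and lower numbers for stronger inhibition of growth. Compound 2 `COc1cc(-c2cc(/C=C/C(=O)c3ccc(N)cc3)[nH]n2)cc(OC)c1OC` gives 1860 nM in this assay, and its number and that of compound 1 lie within the usual scatter of each other. Compound 3 `COc1cc(-c2cc(/C=C/C(=O)c3ccc(Cl)c(Cl)c3)[nH]n2)cc(OC)c1OC` differs from compound 2 by 3,4-dichlorophenyl in place of 4-aminophenyl on a carbonyl carbon. Within the data shown here, no measured pair shows this change, so the size of the step is uncertain; only a small step, if any, beyond the scatter is expected, and for compound 3 the estimated value is 1500 nM (range 500 nM to 4500 nM), which would mean an expected step of a 1.2-fold lower number from compound 2 to compound 3 (0.09 log units; within the scatter).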

Compound 3, concentration for 50% growth inhibition: 13700 nM
Compound 3: the middle estimate sits 9.1-fold (0.96 log units) below what was measured; measured number outside the range, above it.
By their numbers in this assay, from the lowest: compounds 2 and 1 (each within the scatter of the next); then compound 3.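

The group on the carbonyl carbon matters in this assay: 3,4-dichlorophenyl in place of 4-aminophenyl weakens growth inhibition, with a 7.4-fold higher number from compound 2 to compound 3 (0.87 log units; beyond the scatter). Compound 1 and compound 2 lie within the scatter of each other, so this is the first change shown that moves the number beyond it. Nothing measured here explains the step.

Still open, on these data alone, is whether losing the amine or gaining the two chlorines drives the step, as both happen in one swap. A plain phenyl on the same carbonyl carbon would help separate the two.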